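The source may hold more compounds than are shown below. What is called first, only, known or untested is meant among the compounds shown, and "the series" means these compounds.

Compound 3 `COc1cc2cc(Oc3ccc(NC(=O)Nc4ccc(Cl)c(C(F)(F)F)c4)cc3)c(C)nc2cc1OC` stands lowest of the three compounds measured in a functional assay on A549 cells (Homo sapiens) for inhibition, read by sulforhodamine B assay, with a stated time of 48 h, tested at 10 uM (a higher number here means a weaker effect of the compound at the concentration tested, a lower number a stronger effect), giving -17.3%. Its nearest neighbour is compound 2 `COc1cc2cc(Oc3ccc(NC(=O)Nc4cccc(C(F)(F)F)c4)cc3)c(C)nc2cc1OC`, which in this assay gives 3.09%, and the furthest is compound 1 `COc1cc2cc(Oc3ccc(NC(=O)Nc4ccc(C(F)(F)F)cc4)cc3)c(C)nc2cc1OC`, which in this assay gives 32.4%. The measured steps read a number 29.3 percentage points lower from compound 1 to compound 2 (beyond the scatter), a number 49.7 percentage points lower from compound 1 to compound 3 (beyond the scatter) and a number 20.4 percentage points lower from compound 2 to compound 3 (beyond the scatter). Compound 4 `COc1cc2cc(Oc3ccc(NC(=O)Nc4ccc(Cl)c(Cl)c4)cc3)c(C)nc2cc1OC` differs from compound 3 by chloro in place of trifluoromethyl on an aromatic carbon. Going by the values given here, no measured step exchanges these two groups; the only precedent touching a chloro group is the modest step from compound 2 to compound 3, and it does not directly predict this exchange. Compound 4 is therefore expected to stay close to compound 3, with a step of a number 7.3 percentage points higher from compound 3 to compound 4 (within the scatter) within the scatter. Compound 4 is estimated at -10%, within -35% to 20%.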

Compound 4, a percentage reported as activity, at one concentration (the size of the read-out at that concentration, not a potency): 4.35%
Beside the measured number, compound 4's estimate is 14.4 percentage points below it; measured number inside the range.
By their numbers in this assay, from the lowest: compound 3; then compounds 2 and 4 (each within the scatter of the next); then compound 1.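

In this assay, chloro and trifluoromethyl are not interchangeable at this place, ortho to a chloro group (a number 21.7 percentage points higher from compound 3 to compound 4 (beyond the scatter)). Yet the 3,4-dichlorophenyl group stays level with the 3-(trifluoromethyl)phenyl group (a number 1.3 percentage points higher from compound 2 to compound 4 (within the scatter)) and keeps a clear difference from the 4-(trifluoromethyl)phenyl group (a number 28.1 percentage points lower from compound 1 to compound 4 (beyond the scatter)). No evidence at hand accounts for these steps. Going by these compounds, it remains open whether a methoxy group or an amine at this place would read like chloro or like trifluoromethyl. The reading at a single concentration tells only of a stronger or weaker effect at that concentration.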